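This account rests on a few compounds, and the source may have more. Where it says the series, first, only, none or still open, it means among the compounds named here.

Measured so far in an assay on isolated protein for inhibition of Amine oxidase [flavin-containing] A (Homo sapiens), read by fluorescence and Amplex Red, with a stated time of 15 min, tested at 50 uM; a higher number here means more inhibition at the concentration tested (going by the name of the read-out), a lower number less inhibition:

Compound 1, `C#CCN(C)Cc1cn(-c2cc(NC(=S)NCC)ncn2)cn1`, gives 20.2%.
Compound 2, `C#CCN(CCC)Cc1cn(-c2cc(NC(=S)NCC)ncn2)cn1`, gives 1.76%.
Compound 3, `C#CCN(CCCC)Cc1cn(-c2cc(NC(=S)NCC)ncn2)cn1`, gives 2.43%.

Compound 3 stands second highest of the three numbers. Its nearest neighbour is compound 2, and the step of a number 0.7 percentage points higher from compound 2 to compound 3 (within the scatter) lies within the scatter, so the two are not told apart. Compound 1 is the furthest, and the step of a number 17.8 percentage points lower from compound 1 to compound 3 (beyond the scatter) is beyond the scatter.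

Compound 4, `C#CCN(Cc1ccccc1)Cc1cn(-c2cc(NC(=S)NCC)ncn2)cn1`, is not yet measured. It differs from compound 3 by phenyl in place of propyl on a saturated chain carbon bound to an amine nitrogen.

Within the data shown here, two measured steps bear on this place. The step of a number 18.4 percentage points lower from compound 1 to compound 2 (beyond the scatter) and the step of a number 17.8 percentage points lower from compound 1 to compound 3 (beyond the scatter) both lowered the number by a modest amount when a larger group entered on the saturated chain carbon bound to the amine nitrogen; the step of a number 0.7 percentage points higher from compound 2 to compound 3 (within the scatter) added nothing beyond the scatter. Among the measured compounds shown here, no measured compound carries a phenyl at this place, so the data lack a direct comparison. Since the two larger groups already sit close together in this assay, a further enlargement is expected to give a step of a number 1.6 percentage points higher from compound 3 to compound 4 (within the scatter), none beyond the scatter. Compound 4 is therefore estimated at 4%, between -3% and 14%.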

Compound 4, a percentage reported as inhibition, at one concentration (the size of the read-out at that concentration, not a potency): 17.8%
Estimate against measurement, compound 4: 13.8 percentage points below, and the stated range ends below it.
By their numbers in this assay, from the lowest: compounds 2 and 3 (each within the scatter of the next); then compounds 4 and 1 (each within the scatter of the next).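

In this assay, the drop seen with ethyl and propyl does not hold for every larger group on the saturated chain carbon bound to an amine nitrogen: phenyl gives a number 15.4 percentage points higher from compound 3 to compound 4 (beyond the scatter) and a number 16 percentage points higher from compound 2 to compound 4 (beyond the scatter). Set against hydrogen at this place, phenyl gives a number 2.4 percentage points lower from compound 1 to compound 4 (within the scatter), so the group with the most heavy atoms of the series cannot be told apart from the smallest, and size alone does not order these numbers. Nothing available here accounts for this difference between phenyl and the two saturated chains.

The compounds shown leave open whether the ring itself or its aromatic character matters, which a cyclohexyl at the same place would test. They also leave open how a pyridine, or a phenyl carrying a methoxy or a chlorine, would compare.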